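Ring change at the aromatic carbon and microsomal stability

A few compounds are considered here, and "the series" means these few. Any claim that something is new, unique, unknown or untested is made for them only; others in the source may bear on it.

compound 1, `CNC(=O)c1nnc(NC(=O)C2CC2)cc1Nc1cccc(-c2cccnn2)c1OC`: 60%
compound 2, `CNC(=O)c1nnc(NC(=O)C2CC2)cc1Nc1cccc(-c2ccccn2)c1OC`: 79%

In an ADME assay on microsomes from liver (Homo sapiens) for metabolic stability, with a stated time of 10 min (on this read-out lower numbers stand for a less stable compound and higher numbers for a more stable compound), compound 2 gives the higher of the two numbers, with compound 1 the nearest neighbour. Within the data shown here, the only measured step, a number 19 percentage points higher from compound 1 to compound 2 (beyond the scatter), lies beyond the scatter. Compound 3, `CNC(=O)c1nnc(NC(=O)C2CC2)cc1Nc1cccc(-c2ccncn2)c1OC`, carries the change (pyrimidin-4-yl in place of pyridin-2-yl on an aromatic carbon). That step bears on it, since a six-membered aromatic ring with 2 hetero atoms again enters, as in compound 1; a modest drop in this assay is therefore expected, though pyrimidin-4-yl is not pyridazin-3-yl and the size is uncertain. Compound 3 is expected to give 68%, range 52% to 84%. The expected step is a number 11 percentage points lower from compound 2 to compound 3 (beyond the scatter).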

Compound 3, percent of the compound remaining: 48%
For compound 3 the middle estimate is 20 percentage points above the measured one, and the stated range ends above it.
By their numbers in this assay, from the lowest: compound 3; then compound 1; then compound 2.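

In this assay, the pyrimidin-4-yl change gives a number 31 percentage points lower from compound 2 to compound 3 (beyond the scatter) and the swap from pyridazin-3-yl gives a number 12 percentage points lower from compound 1 to compound 3 (beyond the scatter) at this position. Two six-membered aromatic rings with 2 hetero atoms therefore do not read alike here, so the count of hetero atoms alone does not set the result. Among the three compounds, pyridin-2-yl stays clearly ahead of both.

Still open, from the compounds shown here alone, is how a phenyl ring without ring nitrogen, or a non-aromatic morpholine, would read at this place in this assay. Nothing available here explains the gap between these rings.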